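Cytotoxicity notes: amine-bearing esters on the shared core

The source may hold more compounds than are shown below. What is called first, only, known or untested is meant among the compounds shown, and "the series" means these compounds.

compound 1 `CCN(CC)CC(=O)OC1CC2(N3CCCCC3)CC(c3ccccc3)C1C(c1ccccc1)C2` in an ADME assay on L6 cells (Rattus norvegicus) for cytotoxicity, with a stated time of 72 h (on this read-out higher numbers stand for weaker inhibition and lower numbers for stronger inhibition), gives 23900 nM
compound 2 `CC(=O)OC1CC2(N3CCCCC3)CC(c3ccccc3)C1C(c1ccccc1)C2` in this assay gives "not determined" (no result reported)

Compound 2 stands at "not determined" (no result reported) in this assay and so offers no number to start from. Next comes compound 3 `O=C(CN1CCCCC1)OC1CC2(N3CCCCC3)CC(c3ccccc3)C1C(c1ccccc1)C2`, not yet measured. The structural change is piperidin-1-yl in place of hydrogen on a saturated chain carbon bound to a carbonyl carbon and can also be read as acetyl to ((piperidin-1-yl)methyl)carbonyl. With no number for compound 2, the step has no measured baseline. For the measured compounds named here, the only anchor is compound 1 at 23900 nM in this assay, which also bears an amine on the saturated chain carbon bound to the carbonyl carbon. Compound 3 is expected to sit near compound 1, with no shift beyond the scatter and no favoured direction. In this assay the estimated value for compound 3 is 20000 nM, with 8000 nM to 50000 nM as the expected range.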

Compound 3, half-maximal inhibitory concentration: 60400 nM
The estimate for compound 3 lay 3.0-fold (0.48 log units) below the measured number; the whole stated range lies below it.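

In this assay piperidin-1-yl in place of diethylamino on a saturated chain carbon bound to a carbonyl carbon brings a 2.5-fold higher number from compound 1 to compound 3 (0.40 log units; beyond the scatter) and so shows that the choice of amine at this place can move the number. Of this pair, compound 3 has the weaker inhibition, although the step is modest. No measurement shown here accounts for the shift.

As far as these compounds go, the step from compound 2 cannot be read, so the effect of either amine relative to the plain acetyl ester remains unknown. Also open, from the compounds shown here alone, is whether a morpholin-4-yl group at this place, or a longer chain between the carbonyl carbon and the amine, would sit nearer compound 1 or compound 3.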